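The source may report more compounds than this note shows. Statements on the series, on what has been measured and on what is new or still open speak of the compounds shown alone.

Compound 1 `Cc1cc(O)c(C(=O)/C=C/c2ccc(F)cc2)c(=O)o1`: > 100000 nM
Compound 2 `Cc1cc(O)c(C(=O)/C=C/c2ccc(F)c(F)c2)c(=O)o1`: 74900 nM

In a functional assay on HCT-116 cells (Homo sapiens) for cytotoxicity, read by MTT assay (on this read-out lower numbers stand for stronger inhibition and higher numbers for weaker inhibition), the entry for compound 1, > 100000 nM, is a limit of the assay and not a number. Compound 3 `Cc1cc(O)c(C(=O)/C=C/c2ccc(-c3ccccc3)cc2)c(=O)o1` carries one structural change from compound 1: phenyl in place of fluoro on an aromatic carbon. Going by the values given here, only one measured step bears on this, an at least 1.3-fold lower number from compound 1 to compound 2 (0.12 log units; that floor lies within the scatter). It puts a fluoro in place of hydrogen rather than adding a phenyl, so it offers only weak guidance. A small move towards lower numbers is therefore expected, an estimated at least 1.6-fold lower number from compound 1 to compound 3 (0.22 log units; that floor lies within the scatter). For compound 3 the expected value is 60000 nM, with an estimated range of 20000 nM to 100000 nM.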

Compound 3, half-maximal inhibitory concentration: > 100000 nM
Compound 3 ended at the assay's limit; the forecaster's own chance of this, stated with the estimate: 40%; middle value at least 1.6-fold (0.22 log units) away from the limit.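

In this assay, going by these compounds alone, compound 1 and compound 3 both end at a limit rather than a number, so no step between them can be read. On these data alone, whether phenyl in place of fluoro changes cytotoxicity at all remains open.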